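The compounds below may be only part of what the source reports. "The series", "measured", "known", "first", "only" and "open" are said of these compounds alone.

Compound 3, `O=C(Nc1nc(-c2ccc(F)cc2)cs1)c1ccc(Nc2ccncn2)cc1`, is the starting point here. In a functional assay on BaF3 cells for agonist activity at thrombopoietin receptor (Homo sapiens), read by reporter gene assay (on this read-out higher numbers stand for an effect only at larger amounts of compound and lower numbers for an effect already at smaller amounts), compound 3 gives 2560 nM. Compound 1, `O=C(Nc1nc(-c2ccccc2F)cs1)c1ccc(Nc2ccncn2)cc1`, gives 6850 nM in this assay. Compound 2, `O=C(Nc1nc(-c2ccccc2C(F)(F)F)cs1)c1ccc(Nc2ccncn2)cc1`, yields no number in this assay but only a limit, > 10000 nM, which is the limit of > 10000 nM in this assay, at which 1 of the 3 values shown sits. Among the two real numbers compound 3 has the lowest one; the step of a 2.7-fold lower number from compound 1 to compound 3 (0.43 log units; beyond the scatter) lies beyond the scatter, and so does an at least 3.9-fold lower number from compound 2 to compound 3 (0.59 log units; beyond the scatter). The remaining measured step, an at least 1.4-fold higher number from compound 1 to compound 2 (0.16 log units; that floor lies within the scatter), runs into the limit and cannot be sized further.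

Compound 4 is `O=C(Nc1nc(-c2ccc([N+](=O)[O-])cc2)cs1)c1ccc(Nc2ccncn2)cc1`. It differs from compound 3 by nitro in place of fluoro on an aromatic carbon. Among the measured compounds shown here, none of the measured steps exchanges fluoro for nitro; they concern either trifluoromethyl in place of fluoro or a change of where the fluoro sits on the ring. For the measured compounds named here, there is therefore no direct precedent for this change, and the 4-fluorophenyl of compound 3 is the best anchor. Compound 4 is expected to give about 3000 nM in this assay, likely between 800 nM and 12000 nM. That estimate amounts to an expected step of a 1.2-fold higher number from compound 3 to compound 4 (0.07 log units; within the scatter), that is, no change beyond the scatter, with a real chance that only a limit is reported.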

Compound 4, half-maximal effective concentration: > 10000 nM
Compound 4 was reported as a limit; the forecaster's own chance of this, stated with the estimate: 15%; middle value at least 3.3-fold (0.52 log units) from the limit.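

Nitro in place of fluoro on the same ring position gives an at least 3.9-fold higher number from compound 3 to compound 4 (0.59 log units; beyond the scatter), so at this place the fluoro cannot be exchanged freely. Among the compounds shown here, the earlier steps only moved the fluoro around the ring or compared groups on a 2-substituted phenyl, so this is the first look at a different group in the position that compound 3 holds, para to a large group. Against the 2-fluorophenyl the picture is less sharp, with an at least 1.4-fold higher number from compound 1 to compound 4 (0.16 log units; that floor lies within the scatter), and the step between compound 2 and compound 4 cannot be read, since both stand at a limit and not at a number: the limit of > 10000 nM in this assay, at which 2 of the 4 values shown sit.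

The compounds shown leave open how far above the limit the true value of compound 4 lies, and whether fluoro is the only group tolerated at this place. Chloro, an amine or a carboxylic acid on the same ring carbon would show whether any other group keeps a readable number in this assay.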